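The compounds below may be only part of what the source reports. "The series", "measured", "known", "first", "only" and "open" are said of these compounds alone.

Of the compounds shown here, two of a shared core have been measured in an assay on HT-29 cells with Methylated-DNA--protein-cysteine methyltransferase (Homo sapiens) as the target, with a stated time of 30 min; a higher number here means that more compound is needed for the effect, a lower number that less compound is needed. Compound 1, `Fc1nc(OCc2ccccc2)c2[nH]cnc2n1`, gives 48 uM. Compound 2, `CNc1nc(OCc2ccccc2)c2[nH]cnc2n1`, gives 160 uM. Of these two numbers, compound 2 stands highest, so more of it is needed than of compound 1. Among the measured compounds shown here, the only measured step is a 3.3-fold higher number from compound 1 to compound 2 (0.52 log units; beyond the scatter).

Compound 3, `CN(C)c1nc(OCc2ccccc2)c2[nH]cnc2n1`, differs from compound 2 by methyl in place of hydrogen on a nitrogen on an aromatic ring. For the measured compounds named here, no measured pair repeats this exact change, so the one step available, from fluoro to methylamino at the same aromatic carbon, is the closest guide: it added atoms at this position and raised the number modestly. Adding one more carbon at the same nitrogen is therefore expected to move the number in the same direction, if at all, by a small amount that may stay within the scatter. For compound 3 the expected step is a 1.6-fold higher number from compound 2 to compound 3 (0.19 log units; within the scatter), giving an estimate of 250 uM for compound 3, with a range from 100 uM to 600 uM.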

Compound 3, concentration for half-maximal effect: 200 uM
Estimate against measurement, compound 3: 1.3-fold (0.10 log units) above; measured number inside the range.
By their numbers in this assay, from the lowest: compound 1; then compounds 2 and 3 (each within the scatter of the next).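

In this assay, the step from methylamino to dimethylamino is a 1.3-fold higher number from compound 2 to compound 3 (0.10 log units; within the scatter), so compound 2 and compound 3 cannot be told apart, and the hydrogen on this nitrogen can be replaced by a methyl without a change that can be read. The step of a 4.2-fold higher number from compound 1 to compound 3 (0.62 log units; beyond the scatter) lies beyond the scatter, so among these three compounds the clear difference at this aromatic carbon is between fluoro and the two nitrogen groups, not between the two nitrogen groups themselves. Nothing available explains this result.

The compounds shown leave open how the number would respond to a plain amino group, or to a longer chain such as ethyl on this nitrogen. They also leave open whether chlorine in place of fluoro would stay close to compound 1.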